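Clearance in the series: compound 2 toward compound 4

The source may hold more compounds than are shown below. What is called first, only, known or untested is meant among the compounds shown, and "the series" means these compounds.

Three members of the series have numbers in an ADME assay on microsomes from liver (Homo sapiens) for metabolic stability, read by LC-MS, using NADPH, with stated times of 10 min and 45 min, tested at 1 uM; on this read-out higher numbers stand for fast clearance and lower numbers for slow clearance. Compound 1 `COC(c1cc(Cl)c2c(c1Cl)C(=O)N(Cc1c(C)cc(C)[nH]c1=O)CC2)C1CCOCC1` gives 130 uL/min; 129 uL/min (2 entries) in this assay, and the repeat entries the several entries of compound 1 in this assay, 130 uL/min; 129 uL/min (2 entries) agree with each other. Compound 3 `COC(c1cc(Cl)c2c(c1Cl)C(=O)N(Cc1c(C)cc(C)[nH]c1=O)CC2)C1CCS(=O)(=O)CC1` gives 15 uL/min; 40 uL/min (2 entries) in this assay, where the repeat entries the several entries of compound 3 in this assay, 15 uL/min; 40 uL/min (2 entries) sit further apart. Within the data shown here, compound 2 `Cc1cc(C)c(CN2CCc3c(Cl)cc([C@H](CO)[C@H]4CCCO4)c(Cl)c3C2=O)c(=O)[nH]1` gives 51.6 uL/min in this assay, the only number it has; two further entries for it carry no single number. On the numbers shown, compound 2 sits between compound 1 and compound 3, the gap to each of them resting on the values alone.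

Compound 4 `Cc1cc(C)c(CN2CCc3c(Cl)cc([C@H](C)CO)c(Cl)c3C2=O)c(=O)[nH]1` is not yet measured. It differs from compound 2 by a group of 4 heavy atoms (3 carbon, 1 oxygen; no ring) in place of a group of 8 heavy atoms (6 carbon, 2 oxygen; one five-membered non-aromatic ring with 1 hetero atom), on an aromatic carbon, so that the five-membered non-aromatic ring with one hetero atom leaves and a 1-(hydroxymethyl)ethyl group enters at the same aromatic carbon.

Among the measured compounds shown here, no measured pair shows this change, so the expected step is read off compound 2 alone. The step from compound 2 to compound 4 is expected to lie within the scatter or a little toward slower clearance, a 1.4-fold lower number from compound 2 to compound 4 (0.13 log units; within the scatter). Compound 4 is therefore estimated at 38 uL/min in this assay, with a range from 15 uL/min to 95 uL/min.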

Compound 4, intrinsic clearance in a liver preparation (reported as CLH), per the amount of preparation that the assay uses: 15.8 uL/min
The estimate for compound 4 lay 2.4-fold (0.38 log units) above the measured number, within the range that was stated.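

Among these compounds, this aromatic carbon, ortho to a chloro group and para to a fused ring, gives the first single-place change that can be read in this assay, with the 1-(hydroxymethyl)ethyl group giving a 3.3-fold lower number from compound 2 to compound 4 (0.51 log units; beyond the scatter). Both groups count 1 hydrogen-bond donor, so the step does not go with a change in donor count, and the five-membered non-aromatic ring is not needed for the lower number. The step is modest and rests on one number for each compound, while repeat entries elsewhere in the series can lie further apart: the several entries of compound 3 in this assay, 15 uL/min; 40 uL/min (2 entries)

Going by these compounds, whether the lower number follows the loss of the ring or simply the smaller group stays open. An open-chain ether of similar size, or an amine in place of the hydroxyl at the same aromatic carbon, would help to separate these readings.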